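Cyclohexyl for isobutyl at the amide nitrogen

A few compounds are considered here, and "the series" means these few. Any claim that something is new, unique, unknown or untested is made for them only; others in the source may bear on it.

Measured compounds in an ADME assay on HELF cells (Homo sapiens) for cytotoxicity, with a stated time of 3 days; a lower number here means that less compound is tolerated, a higher number that more compound is tolerated:
- compound 1 `CC(C)CNC(=O)[C@H](C)NC(=O)[C@@]1(Cc2ccccc2)CCN1C(=O)OCc1ccccc1`, a limit only: > 100000 nM
- compound 2 `C[C@H](NC(=O)[C@]1(Cc2ccccc2)CCN1C(=O)OCc1ccc([N+](=O)[O-])cc1)C(N)=O`, a limit only: > 100000 nM
- compound 3 `C[C@H](NC(=O)[C@]1(Cc2ccccc2)CCN1C(=O)Oc1cccc2ccccc12)C(N)=O`, a limit only: > 100000 nM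

Compound 1 stands at the limit of this assay, and nothing more is known of its position. For the measured compounds named here, every value sits at that same limit, as the limit of > 100000 nM in this assay, at which 3 of the 3 values shown sit, shows, so the one measured step, a step that the two limits leave unreadable from compound 2 to compound 3, cannot be read in either direction. Compound 4 `C[C@H](NC(=O)[C@@]1(Cc2ccccc2)CCN1C(=O)OCc1ccccc1)C(=O)NC1CCCCC1` differs from compound 1 by cyclohexyl in place of isobutyl on an amide-type nitrogen. Going by the values given here, no measured step bears on this change, and the series offers no spread of numbers from which a direction could be taken. Compound 4 is therefore expected near 150000 nM, in the range 50000 nM to 500000 nM. The expected step that the limit leaves unreadable from compound 1 to compound 4 is none beyond the scatter, most likely again reported as a limit.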

Compound 4, half-maximal cytotoxic concentration: 46000 nM
For compound 4 the middle estimate is 3.3-fold (0.51 log units) above the measured one; measured number outside the range, below it.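

In this assay, cyclohexyl in place of isobutyl on an amide-type nitrogen gives an at least 2.1-fold lower number from compound 1 to compound 4 (0.33 log units; beyond the scatter). For the compounds shown here, compound 4 holds the only value that is not a limit, so this nitrogen is a place where the number can move. The step is a minimum only, set by the ceiling of the series: the limit of > 100000 nM in this assay, at which 3 of the 4 values shown sit.

Still open, going by these compounds, is whether cyclopentyl, phenyl or a longer chain on this nitrogen gives a readable number. Also open, on these data alone, is whether cyclohexyl gives a similar step alongside the 4-nitrobenzyl or naphthalen-1-yl groups.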